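The source may report more compounds than this note shows. Statements on the series, on what has been measured and on what is new or still open speak of the compounds shown alone.

Working notes on the series. The shared core is carried by compound 1 `COc1c(OCCCCN2CCN(C)CC2)cc(O)c2c(=O)cc(-c3ccc(F)cc3)oc12`, compound 2 `CCN(CC)CCCOc1c(OCc2ccccc2)cc(O)c2c(=O)cc(-c3ccccc3)oc12` and compound 3 `O=c1cc(-c2ccccc2)oc2c(OCCCN3CCCC3)c(OCc3ccccc3)cc(O)c12`; all three have been run in a functional assay on MCF7 cells (Homo sapiens) for cytotoxicity, read by MTT assay, with a stated time of 72 h; on this read-out lower numbers stand for stronger inhibition and higher numbers for weaker inhibition. Compound 1 gives 3860 nM, compound 2 gives 3210 nM, and compound 3 gives 2230 nM. Compound 3 thus holds the lowest of the three numbers, but the gaps to compound 2 and to compound 1 both lie within the scatter, so no ordering among the three can be claimed.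

Among the measured compounds shown here, the one single-point step measured so far concerns the amine on the chain: a 1.4-fold lower number from compound 2 to compound 3 (0.16 log units; within the scatter), a change that stays within the scatter.

Compound 4 `CN(C)CCCCOc1c(OCc2ccccc2)cc(O)c2c(=O)cc(-c3ccccc3)oc12` has not been measured. Relative to compound 3 the change is (dimethylamino)methyl in place of pyrrolidin-1-yl on a saturated chain carbon, three bonds along the chain from an oxygen on an aromatic ring. This is again a swap of the amine on the chain, of the same kind as the step from compound 2 to compound 3, and that step was flat. On that basis no movement beyond the scatter is expected in this assay, with the step from compound 3 to compound 4 estimated as a 1.3-fold higher number from compound 3 to compound 4 (0.10 log units; within the scatter). Compound 4 is therefore expected to give about 2800 nM, with a range from 1400 nM to 5600 nM.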

Compound 4, half-maximal inhibitory concentration: 3210 nM
The estimate for compound 4 lay 1.1-fold (0.06 log units) below the measured number, within the range that was stated.
By their numbers in this assay, from the lowest: compounds 3, 2, 4 and 1 (each within the scatter of the next).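

In this assay, the exchange of 3-(pyrrolidin-1-yl)propyl for 4-(dimethylamino)butyl gives a 1.4-fold higher number from compound 3 to compound 4 (0.16 log units; within the scatter); this step removes the ring and alters the chain and the amine together, yet stays within the scatter. With diethylamino as the starting group, the same position gives no change at the digits printed from compound 2 to compound 4 (within the scatter), so compound 2, compound 3 and compound 4 show that this position tolerates these three chain-and-amine combinations without a change that can be read, whether the amine is cyclic or open and whether the chain is propyl or butyl. No evidence beyond these numbers bears on this result.

The steps to compound 4 change the chain and the amine at once, so any separate contributions of the two remain unresolved, including the possibility of opposing contributions that cancel; 3-(dimethylamino)propyl on the same core would separate them. Also open, on these data alone, is whether the position stays this flat when the chain ends in a morpholine or a carboxylic acid rather than in one of these amines.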